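The source may report more compounds than this note shows. Statements on the series, on what has been measured and on what is new or still open speak of the compounds shown alone.

Compound 1 `N=C(N)c1cccc(CN2CC[C@H](NS(=O)(=O)c3ccc(-c4ccccn4)cc3)C2=O)c1` in an assay on isolated protein for inhibition of Trypsin II (Bos taurus) (on this read-out higher numbers stand for weaker inhibition and lower numbers for stronger inhibition), gives > 2900 nM, a limit of the assay.
Compound 2 `N=C(N)c1cccc(CN2CC[C@H](NS(=O)(=O)c3ccc(-c4ccncc4)cc3)C2=O)c1` in this assay gives > 2900 nM, a limit of the assay.
Compound 3 `C[n+]1ccc(-c2ccc(S(=O)(=O)N[C@H]3CCN(Cc4cccc(C(=N)N)c4)C3=O)cc2)cc1` in this assay gives > 2900 nM, a limit of the assay.

Compound 3 therefore stands only at a limit, as do the other two; (the limit of > 2900 nM in this assay, at which 3 of the 3 values shown sit). The steps a step that the two limits leave unreadable from compound 1 to compound 2, a step that the two limits leave unreadable from compound 1 to compound 3 and a step that the two limits leave unreadable from compound 2 to compound 3 are all unreadable for the same reason. Compound 4 `N=C(N)c1cccc(CN2CC[C@H](NS(=O)(=O)c3ccc(-c4cc[n+]([O-])cc4)cc3)C2=O)c1` differs from compound 3 by one oxygen atom in place of one carbon atom, on an aromatic nitrogen. Among the measured compounds shown here, no measured step bears on this change with a readable size, so no direction beyond the scatter is expected in this assay; the expected step is a step that the limit leaves unreadable from compound 3 to compound 4. Compound 4 is estimated at 6000 nM, with a range from 1500 nM to 30000 nM, most likely reported again only as a limit.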

Compound 4, inhibition constant: > 2900 nM
Compound 4: only a limit was reported; the forecaster's own chance of this, stated with the estimate: 80%; the middle value does not contradict the limit.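

The steps from compound 1, compound 2 and compound 3 to compound 4 cannot be read, because all four values are limits: the limit of > 2900 nM in this assay, at which 4 of the 4 values shown sit.

The compounds shown leave open how strongly any of them inhibits in this assay, and whether methyl or oxygen on the aromatic nitrogen matters there.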